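The source may report more compounds than this note shows. Statements on the series, on what has been measured and on what is new or still open speak of the compounds shown alone.

Measured so far:
compound 1, `CCCCC/N=C(\NC#N)Nc1cccnc1`: 20 mg/kg in a functional assay on the whole organism (blood, strain Wistar-Okamoto) with Rattus norvegicus as the target, with a stated time of 5 days; on this read-out higher numbers stand for an effect only at larger amounts of compound and lower numbers for an effect already at smaller amounts.
compound 2, `CCCCCCC/N=C(\NC#N)Nc1cccnc1`: in this assay compound 2 gives only the limit > 50 mg/kg.

Compound 2 stands at the upper end of the two numbers shown; its entry is a limit of the assay, not a number (the limit of > 50 mg/kg in this assay, at which 1 of the 2 values shown sits). Going by the values given here, the only measured step, an at least 2.5-fold higher number from compound 1 to compound 2 (0.39 log units; beyond the scatter), came with ethyl in place of hydrogen on a saturated chain carbon, five bonds along the chain from a double-bonded nitrogen, and it shifted the read-out toward larger doses.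

Compound 3, `CCN(CC)CC/N=C(\NC#N)Nc1cccnc1`, differs from compound 2 as follows: diethylamino in place of pentyl on a saturated chain carbon, two bonds along the chain from a double-bonded nitrogen. Among the compounds with values here, no measured step concerns a nitrogen entering the chain; the step of an at least 2.5-fold higher number from compound 1 to compound 2 (0.39 log units; beyond the scatter) speaks only to chain length, and compound 3 keeps the heavy-atom count of compound 2. A direction for this change therefore cannot be read from the measured compounds, and a limit for compound 3 as well remains a real possibility.

Compound 3 is expected in this assay at about 40 mg/kg, between 10 mg/kg and 100 mg/kg. The expected step is then an at least 1.2-fold lower number from compound 2 to compound 3 (0.09 log units; that floor lies within the scatter).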

Compound 3, minimum effective dose: > 8 mg/kg
Compound 3: a limit, no number; the forecaster's own chance of this, stated with the estimate: 40%; the middle value lies beyond the limit too.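

In this assay compound 3 gives > 8 mg/kg, a limit and not a number, so the steps from compound 1 and from compound 2 to compound 3 cannot be read: the limit of > 8 mg/kg in this assay, at which 1 of the 3 values shown sits. The entry for compound 2 is also a limit: the limit of > 50 mg/kg in this assay, at which 1 of the 3 values shown sits. The compounds shown leave open whether diethylamino in place of pentyl shifts the minimum effective dose, and in which direction.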